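Adding One Methoxy to a Weak Growth Inhibitor

A few compounds are considered here, and "the series" means these few. Any claim that something is new, unique, unknown or untested is made for them only; others in the source may bear on it.

In a functional assay on MCF7 cells (Homo sapiens) for inhibition, read by MTT assay, with a stated time of 24 h (a higher number here means a weaker inhibitor of growth, a lower number a stronger inhibitor of growth), compound 1 `COc1ccc(C(=O)n2c(-c3cn(C)c4ccccc34)nc3ccccc32)cc1OC` gives 10200 nM, while compound 2 `Cn1cc(-c2nc3ccccc3n2C(=O)c2cccc(Br)c2)c2ccccc21` gives 63400 nM, the higher of the two numbers and so the weaker result. Compound 3 `COc1ccc2c(c1)c(-c1nc3ccccc3n1C(=O)c1cccc(Br)c1)cn2C` keeps the structure of compound 2 with a single change: methoxy in place of hydrogen on an aromatic carbon. Going by the values given here, only one measured step bears on this, and only loosely. Replacing 3,4-dimethoxyphenyl with 3-bromophenyl on a carbonyl carbon gave a 6.2-fold higher number from compound 1 to compound 2 (0.79 log units; beyond the scatter), so the compound without methoxy groups had the higher number. The new methoxy sits elsewhere in the molecule, so this is a weak guide, and a modest drop is all that can be expected. The estimated change is a 1.8-fold lower number from compound 2 to compound 3 (0.26 log units; within the scatter). For compound 3 the expected value is 35000 nM, with an estimated range of 11000 nM to 90000 nM.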

Compound 3, concentration for 50% growth inhibition: 52700 nM
For compound 3 the middle estimate is 1.5-fold (0.18 log units) below the measured one; low and high end bracket the measured number.
By their numbers in this assay, from the lowest: compound 1; then compounds 3 and 2 (each within the scatter of the next).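

In this assay, methoxy in place of hydrogen on the six-membered ring of carbon only, within the fused system of two rings, gives a 1.2-fold lower number from compound 2 to compound 3 (0.08 log units; within the scatter). Going by these compounds alone, the earlier step changed only the group on the carbonyl carbon, so this is the first reading of a change on this ring. With 3-bromophenyl on the carbonyl carbon, adding methoxy here leaves compound 2 and compound 3 too close to rank, and the pair remains a single level of weak growth inhibition.

Still open, going by these compounds, is whether an amine or a carboxylic acid on this same carbon would shift the number, and whether methoxy here would do the same with 3,4-dimethoxyphenyl on the carbonyl carbon. No information is available to explain the result for this pair.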